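A few compounds are considered here, and "the series" means these few. Any claim that something is new, unique, unknown or untested is made for them only; others in the source may bear on it.

Among the compounds with values here, in a functional assay on SW-620 cells (Homo sapiens) for inhibition, read by MTT assay, with a stated time of 72 h (a lower number here means a stronger inhibitor, a higher number a weaker inhibitor), compound 2 `COc1cc(NC(C)CCCNC(=O)NNC(=O)Nc2ccc(Br)cc2)c2ncccc2c1` gives 17000 nM, the only actual number so far. Compound 1 `COc1cc(NC(C)CCCNC(=O)NNC(=O)Nc2ccc(F)cc2)c2ncccc2c1` sits at a limit of the assay, > 100000 nM. Compound 3 `COc1cc(NC(C)CCCNC(=O)Nc2ccc(Cl)cc2)c2ncccc2c1` brings a larger change, 4-chlorophenyl in place of ((4-bromophenyl)carbamoyl)amino on an amide-type nitrogen. Within the data shown here, the one measured step, bromo in place of fluoro, gave an at least 5.8-fold lower number from compound 1 to compound 2 (0.76 log units; beyond the scatter), but it covers a far smaller edit and offers only weak guidance here. With no clear direction to go on, the expected step is small, a 1.2-fold higher number from compound 2 to compound 3 (0.07 log units; within the scatter). Compound 3 is estimated at 20000 nM, with an expected range of 5000 nM to 80000 nM.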

Compound 3, half-maximal inhibitory concentration: 28000 nM
Estimate against measurement, compound 3: 1.4-fold (0.15 log units) below, and the stated range covers the measured number.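

Replacing ((4-bromophenyl)carbamoyl)amino with 4-chlorophenyl on the amide-type nitrogen gives a 1.6-fold higher number from compound 2 to compound 3 (0.22 log units; within the scatter) in this assay, so the larger group is not required for the activity of compound 2. Replacing ((4-fluorophenyl)carbamoyl)amino with 4-chlorophenyl gives an at least 3.5-fold lower number from compound 1 to compound 3 (0.55 log units; beyond the scatter). The size of this step is only a minimum, since the value of compound 1 is a limit: the limit of > 100000 nM in this assay, at which 1 of the 3 values shown sits.

From the compounds shown here alone, the result of a 4-bromophenyl group on that nitrogen remains open, so the change of group and the change of halogen cannot be separated. Going by these compounds, the effect of an unsubstituted phenyl or a carboxylic acid there also remains open.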